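Adding a Hydroxy Group to a Benzyl Carbazate Hydrazone

The source may hold more compounds than are shown below. What is called first, only, known or untested is meant among the compounds shown, and "the series" means these compounds.

Measured compounds:
compound 1 `COc1cc(/C=N/NC(=O)OCc2ccccc2)cc(OC)c1O` gives 45%
compound 2 `COc1cc(/C=N/NC(=O)OCc2ccccc2)ccc1O` gives 73%
compound 3 `O=C(N/N=C/c1ccc(O)c(O)c1)OCc1ccccc1` gives 48%

All three compounds were tested in a functional assay on cells (Mus musculus) for cytotoxicity, read by MTT assay, with a stated time of 24 h, tested at 1 uM; on this read-out lower numbers stand for a weaker effect and higher numbers for a stronger effect at the one concentration tested. On these numbers compound 2 stands highest: the nearest is compound 3, with a number 25 percentage points lower from compound 2 to compound 3 (beyond the scatter), and the furthest is compound 1, with a number 28 percentage points higher from compound 1 to compound 2 (beyond the scatter) read in the other direction.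

Compound 4 `COc1cc(/C=N/NC(=O)OCc2ccccc2)c(O)cc1O` is not yet measured. It differs from compound 2 in one place: hydroxy in place of hydrogen on an aromatic carbon. Among the measured compounds shown here, no measured step makes exactly this change, but two steps alter the substitution pattern of the same ring. Removing a methoxy, from compound 1 to compound 2, gave a modest rise, while turning a methoxy into a hydroxy, from compound 2 to compound 3, gave a modest fall. Both steps were beyond the scatter and of similar size, so adding a further hydroxy is expected to shift the read-out modestly, more likely downward, as in the step from compound 2 to compound 3.

For compound 4 the expected step is a number 18 percentage points lower from compound 2 to compound 4 (beyond the scatter), giving an estimate of 55% in this assay, with a range from 35% to 78%.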

Compound 4, a percentage reported as activity, at one concentration (the size of the read-out at that concentration, not a potency): 43%
Estimate against measurement, compound 4: 12 percentage points above, and the stated range covers the measured number.
By their numbers in this assay, from the lowest: compounds 4, 1 and 3 (each within the scatter of the next); then compound 2.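

In this assay, placing a hydroxy on an aromatic carbon that carried only hydrogen, ortho to a large group and para to a methoxy group, gives a number 30 percentage points lower from compound 2 to compound 4 (beyond the scatter). Among the compounds shown here, the earlier steps only removed a methoxy or turned a methoxy into a hydroxy, so this is the first sign that this previously unsubstituted carbon is sensitive to an added group, and that the read-out here falls when a hydroxy is added. Nothing available explains this fall.

The compounds shown leave open whether the fall belongs to the hydroxy itself or would follow any group at this carbon, such as an amine, a fluorine atom or a carboxylic acid. A single read-out at one concentration also shows only whether the effect of these compounds is stronger or weaker at that concentration.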